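The compounds below may be only part of what the source reports. "The series", "measured", "known", "first", "only" and "open" are said of these compounds alone.

Three compounds share one core, a cyanoguanidine carrying an imidazole-ended chain on one side and an aryl-ended chain on the other. Compound 1 `N#C/N=C(\NCCCc1ccccc1)NCCCc1c[nH]cn1` gives 5.25 in an in vitro functional assay on Sf9 cells for antagonist activity at histamine H2 receptor (Homo sapiens); a lower number here means a less potent compound, a higher number a more potent compound, by a factor of ten per unit of this negative logarithm. Compound 2 `N#C/N=C(\NCCCCc1ccccc1)NCCCCc1c[nH]cn1`, with both chains lengthened by one carbon, gives 5.03. Compound 3 `N#C/N=C(/NCCCCc1c[nH]cn1)NCCCc1ccc(F)cc1` gives 5.28; its number is the top of the three, yet its gaps to compound 1 and compound 2 both lie within the scatter, so the three cannot be ranked. Going by the values given here, the one single-point step recorded, a number 0.25 log units higher from compound 2 to compound 3 (within the scatter), is likewise within the scatter.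

Compound 4 `N#C/N=C(/NCCCCc1c[nH]cn1)NCCCc1cccnc1` follows from compound 3 by the change (pyridin-3-yl in place of 4-fluorophenyl on a saturated chain carbon, three bonds along the chain from an amine nitrogen). Among the compounds with values here, no measured step swaps an aromatic ring for one holding a nitrogen, so the only guide is that the one ring change seen, from compound 2 to compound 3, stayed within the scatter. A step within the scatter is therefore expected, a number 0.08 log units lower from compound 3 to compound 4 (within the scatter). Compound 4 is estimated at 5.2, between 4.7 and 5.7.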

Compound 4, negative logarithm of the antagonist equilibrium constant: 5.92
Beside the measured number, compound 4's estimate is 0.72 log units below it; the whole stated range lies below it.
By their numbers in this assay, from the lowest: compounds 2, 1 and 3 (each within the scatter of the next); then compound 4.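

In this assay, the ring at the end of the chain now makes a difference: pyridin-3-yl in place of 4-fluorophenyl, on a saturated chain carbon, three bonds along the chain from an amine nitrogen, gives a number 0.64 log units higher from compound 3 to compound 4 (beyond the scatter). The earlier ring change stayed within the scatter, whereas the same pyridin-3-yl ring also gives a number 0.89 log units higher from compound 2 to compound 4 (beyond the scatter), so the end of this chain can respond to a change of ring. The entering ring holds a nitrogen and one hydrogen-bond acceptor, while the leaving ring holds a fluorine and no acceptor, but nothing available here accounts for the gain.

An unsubstituted phenyl ring on these same chains would help separate the effect of adding the ring nitrogen from that of losing the fluorine. Pyridin-2-yl and pyridin-4-yl would show whether the nitrogen's place in the ring matters.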